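The source may report more compounds than this note shows. Statements on the series, on what has been measured and on what is new or still open speak of the compounds shown alone.

In a functional assay on COLO 205 cells (Homo sapiens) for inhibition, read by MTT assay, with a stated time of 24 h (on this read-out higher numbers stand for weaker inhibition and lower numbers for stronger inhibition), three compounds have been examined so far, and each of them returned only a limit of the assay rather than a number. Compound 1, with the structure `CCCCCCCCCCn1cc(/C=[N+](\[O-])c2ccccc2)nn1`, gave > 100000 nM, which is a limit. Compound 2, `[O-]/[N+](=C\c1cn(-c2ccc(F)cc2)nn1)Cc1ccccc1`, likewise gave only the limit > 100000 nM. Compound 3, `CCCCCCCCn1cc(/C=[N+](\[O-])Cc2ccccc2)nn1`, stands at the limit > 100000 nM as well, the point at which every measured value in this series sits (the limit of > 100000 nM in this assay, at which 3 of the 3 values shown sit). Compound 3 therefore cannot be ranked against the other two; all that can be said is that none of the three reached a measurable half-maximal inhibitory concentration within the range of this assay.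

Compound 4, `CCCCCCCCCCn1cc(/C=[N+](\[O-])Cc2ccccc2)nn1`, remains to be measured. It differs from compound 3 by ethyl in place of hydrogen on a saturated chain carbon, eight bonds along the chain from an aromatic nitrogen, in words ethyl in place of hydrogen on a saturated chain carbon, eight bonds along the chain from an aromatic nitrogen. Among the measured compounds shown here, no step between measured compounds in this assay is available, so no size of effect can be read from the data for a change of this kind. Compound 4 is expected to stay at the limit as well, because compound 3 itself gives only the limit > 100000 nM. The step from compound 3 to compound 4 is estimated as a step that the limit leaves unreadable from compound 3 to compound 4, that is nothing beyond the scatter. Compound 4 is accordingly estimated at 150000 nM, with a range from 50000 nM to 500000 nM.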

Compound 4, half-maximal inhibitory concentration: > 100000 nM
Compound 4: a limit, no number; the forecaster's own chance of this, stated with the estimate: 85%; the middle value is on the limit's open side.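

Compound 4 gives > 100000 nM in this assay and this is a limit. Among the compounds shown here, no step from compound 3 or compound 1 to compound 4 can be read, and the series stays at a single point: the limit of > 100000 nM in this assay, at which 4 of the 4 values shown sit. The compounds shown leave open whether any of them differ in inhibition, and which change would bring a measurable half-maximal inhibitory concentration.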